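The compounds below may be only part of what the source reports. "The series", "measured", "known", "first", "only" and "open" are said of these compounds alone.

For the measured compounds named here, in a functional assay on PC-3 cells (Homo sapiens) for antiproliferative activity, read by MTT assay, with a stated time of 48 h (a higher number here means a weaker inhibitor, a lower number a stronger inhibitor), compound 2 `COc1ccc(CN(C(=O)CSc2nc3ccccc3s2)c2cc(OC)c(OC)c(OC)c2)cc1O` gives 2110 nM, the lowest of the three numbers so far. Compound 1 `COc1ccc(CN(C(=O)CSc2nc3ccccc3s2)c2cc(OC)c(OC)c(OC)c2)cc1N=[N+]=[N-]` gives 14400 nM, and compound 3 `COc1cc(N(Cc2ccccc2)C(=O)CSc2nc3ccccc3s2)cc(OC)c1OC` gives 54100 nM. Compound 4 `COc1ccc(CN(C(=O)CSc2nc3cc(Br)ccc3s2)c2cc(OC)c(OC)c(OC)c2)cc1O` differs from compound 2 by one change: bromo in place of hydrogen on an aromatic carbon. The measured steps bear on this only indirectly. The step of a 6.8-fold lower number from compound 1 to compound 2 (0.83 log units; beyond the scatter) is modest, the step of a 3.8-fold higher number from compound 1 to compound 3 (0.57 log units; beyond the scatter) is also modest, and the step of a 26-fold higher number from compound 2 to compound 3 (1.41 log units; beyond the scatter) is large. All three alter the group on the saturated chain carbon bound to the amide-type nitrogen. Going by the values given here, none changes the ring that receives the bromo, so the series offers no precedent for its size or direction. No step beyond the scatter is therefore expected in this assay, though with wide uncertainty. The estimated step is a 1.1-fold higher number from compound 2 to compound 4 (0.04 log units; within the scatter). Compound 4 is expected at 2300 nM, within an estimated range of 650 nM to 8000 nM.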

Compound 4, half-maximal inhibitory concentration: 8210 nM
Beside the measured number, compound 4's estimate is 3.6-fold (0.55 log units) below it, outside the stated range (above it).
By their numbers in this assay, from the lowest: compound 2; then compounds 4 and 1 (each within the scatter of the next); then compound 3.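

In this assay, for the compounds shown here, bromo in place of hydrogen gives a 3.9-fold higher number from compound 2 to compound 4 (0.59 log units; beyond the scatter), the first measured step on the six-membered aromatic ring of carbon only, part of a fused system of two rings. Substitution on this ring is therefore not silent: the earlier steps changed only the group on the saturated chain carbon, and this one shows that a single bromo on an aromatic carbon of the ring moves the number beyond the scatter, towards weaker inhibition. Nothing available explains this loss.

With only hydrogen and bromo shown at this carbon, it remains open whether the loss is particular to bromo or would also follow fluoro, an amine or a carboxylic acid there. As far as these compounds go, the step is also read only with the 3-hydroxy-4-methoxyphenyl group in place, so its size with 3-azido-4-methoxyphenyl or phenyl remains unknown.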